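From Carboxy to Fluoro in a Growth Inhibitor

A few compounds are considered here, and "the series" means these few. Any claim that something is new, unique, unknown or untested is made for them only; others in the source may bear on it.

In a functional assay on DU-145 cells (Homo sapiens) for inhibition, read by trypan blue exclusion, with a stated time of 96 h (a higher number here means a weaker inhibitor of growth, a lower number a stronger inhibitor of growth), compound 1 (`O=C(O)c1ccc(C(=O)/C(=C\c2ccc(F)c([N+](=O)[O-])c2)SCc2ccc(F)cc2)cc1`) gives 1000 nM as the lower of two numbers, and compound 2 (`O=C(O)c1ccc(C(=O)/C(=C\c2ccc(F)c([N+](=O)[O-])c2)SCc2ccc(Cl)cc2)cc1`) gives 50000 nM as the higher. Going by the values given here, that single measured step (a 50-fold higher number from compound 1 to compound 2 (1.70 log units; beyond the scatter)) is chloro in place of fluoro on an aromatic carbon, in another part of the structure, so it shows only that one small exchange can move this number far. Compound 3 (`O=C(/C(=C\c1ccc(F)c([N+](=O)[O-])c1)SCc1ccc(F)cc1)c1ccc(F)cc1`) has fluoro in place of carboxy on an aromatic carbon, para to a large group (fluoro in place of carboxy on an aromatic carbon). Among the compounds with values here, no measured step covers this change, but a step to a higher number in this assay is expected (a 4.0-fold higher number from compound 1 to compound 3 (0.60 log units; beyond the scatter)). The estimated value for compound 3 is 4000 nM (500 nM to 40000 nM).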

Compound 3, concentration for 50% growth inhibition: 1000 nM
Compound 3: the middle estimate sits 4.0-fold (0.60 log units) above what was measured; the range from low to high includes it.
By their numbers in this assay, from the lowest: compounds 1 and 3 (each within the scatter of the next); then compound 2.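

In this assay, fluoro in place of carboxy on an aromatic carbon gives no change at the digits printed from compound 1 to compound 3 (within the scatter). At this place, para to a large group, the carboxy group is thus not needed to reach the number of compound 1, whereas the earlier step showed only how far one small exchange elsewhere in the structure can move it. Nothing at hand explains why these two groups read alike.

Going by these compounds, whether an amine or a methyl group at this place would read the same stays open. So does whether chloro in place of fluoro, the exchange that separated compound 1 from compound 2, would have the same effect on the core of compound 3.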